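The source may hold more compounds than are shown below. What is called first, only, known or untested is meant among the compounds shown, and "the series" means these compounds.

Working notes on the series. In an assay on HEK293 cells for positive allosteric modulation of metabotropic glutamate receptor 2 (Rattus norvegicus), read by thallium flux, with a stated time of 2.5 min (on this read-out lower numbers stand for smaller maximal responses and higher numbers for larger maximal responses), compound 1 `COC(=O)c1ccc(OCCCCOc2ccc(C(=O)CC3CCCC3)c(O)c2C)cc1` gives 12.2%, compound 2 `Cc1c(OCCCCOc2ccc(F)c(C(=O)O)c2)ccc(C(=O)CC(C)C)c1O` gives 84.5% and compound 3 `Cc1cc(OCCCCOc2ccc(C(=O)CC3CCCC3)c(O)c2C)ccc1C(=O)O` gives 83.6%. Compound 3 therefore stands second highest of the three numbers: its nearest neighbour is compound 2, whose number lies within the scatter of its own, and its furthest is compound 1, whose number lies far below it, beyond the scatter. Among the compounds with values here, the only single-place step measured so far is a number 71.4 percentage points higher from compound 1 to compound 3 (beyond the scatter), a large gain.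

Compound 4 `Cc1c(OCCCCOc2ccc(F)c(C(=O)O)c2)ccc(C(=O)CC2CCCC2)c1O` is not yet measured. Relative to compound 3 it carries 3-carboxy-4-fluorophenyl in place of 4-carboxy-3-methylphenyl on an oxygen on a saturated carbon. The step measured so far touches the same oxygen on a saturated carbon but exchanges a different pair of groups, so it does not bear directly on this change; what it does show is that an acid-bearing aryl at this place, as in compound 3, runs high. Compound 2 carries the entering 3-carboxy-4-fluorophenyl group and its number sits within the scatter of that of compound 3. On that basis no step beyond the scatter is expected for compound 4, that is a number 1.6 percentage points lower from compound 3 to compound 4 (within the scatter) is the estimate. Compound 4 is expected to give about 82%, within a range of 66% to 96%.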

Compound 4, largest response reached (reported as percent of maximum), in percent of the reference or control that the assay uses: 81%
Compound 4: middle estimate off by 1 percentage points, on the high side; the measured number falls inside the stated range.
By their numbers in this assay, from the lowest: compound 1; then compounds 4, 3 and 2 (each within the scatter of the next).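

In this assay, 3-carboxy-4-fluorophenyl in place of 4-carboxy-3-methylphenyl on an oxygen on a saturated carbon gives a number 2.6 percentage points lower from compound 3 to compound 4 (within the scatter) and so does not separate these two acid-bearing aryl groups on the cyclopentyl background. Within the data shown here, the first reading at the other place, cyclopentyl in place of isopropyl on a saturated chain carbon bound to a carbonyl carbon, is a number 3.5 percentage points lower from compound 2 to compound 4 (within the scatter) and likewise stays inside the scatter, while the second comparison with the 4-(methoxycarbonyl)phenyl group is a number 68.8 percentage points higher from compound 1 to compound 4 (beyond the scatter) and thus matches the large step already seen with the other acid-bearing aryl group. Nothing measured here accounts for these numbers.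

Still open is whether a free carboxylic acid is required on this aryl group, as the compounds shown include neither a primary amide nor a tetrazole at that place. Also open, going by these compounds, is how a longer chain on the same oxygen, or a group such as a phenyl in place of cyclopentyl or isopropyl, would read in this assay on the shared core.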